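This account rests on a few compounds, and the source may have more. Where it says the series, first, only, none or still open, it means among the compounds named here.

For the measured compounds named here, in a functional assay on K562 cells (Homo sapiens) for inhibition (a higher number here means a weaker inhibitor, a lower number a stronger inhibitor), compound 1 (`CCC(=O)OC1C(C(O)CO)OC2OC(C)(C)OC21`) gives 2400000 nM and compound 2 (`CC(C)(C)CC(=O)OC1C(C(O)CO)OC2OC(C)(C)OC21`) gives 1200000 nM, so compound 2 stands level with the only other measured compound once the scatter is allowed for. Compound 3 (`CC1(C)OC2OC(C(O)CO)C(OC(=O)C3CCCC3)C2O1`) keeps the shared core but has cyclopentyl in place of neopentyl on a carbonyl carbon. Going by the values given here, only one measured step bears on this change. That step, a 2.0-fold lower number from compound 1 to compound 2 (0.30 log units; within the scatter), also altered the chain on the carbonyl carbon and stayed within the scatter. Among the compounds with values here, no measured compound carries a ring in this place, so the evidence is thin, and nothing in it points to a shift in either direction. In this assay, the expected step, a 1.1-fold higher number from compound 2 to compound 3 (0.03 log units; within the scatter), therefore stays within the scatter. For compound 3 the estimated value is 1300000 nM, with an expected range from 600000 nM to 2800000 nM.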

Compound 3, half-maximal inhibitory concentration: 2500000 nM
For compound 3 the middle estimate is 1.9-fold (0.28 log units) below the measured one; measured number inside the range.
By their numbers in this assay, from the lowest: compounds 2, 1 and 3 (each within the scatter of the next, the first and the last beyond it).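

In this assay, for the compounds shown here, putting a ring on the carbonyl carbon produces the first step to pass the scatter: cyclopentyl in place of neopentyl gives a 2.1-fold higher number from compound 2 to compound 3 (0.32 log units; beyond the scatter), though the step remains modest. Cyclopentyl in place of ethyl gives a 1.0-fold higher number from compound 1 to compound 3 (0.02 log units; within the scatter), so compound 3 stands level with compound 1, and compound 2 is separated from compound 3 but not from compound 1. Nothing available explains why neopentyl and cyclopentyl part slightly here.

Going by these compounds, whether an amine, a carboxylic acid, a six-membered ring or a longer chain on this carbonyl carbon would give a larger step remains open. The three compounds shown carry only carbon groups in this place, and they do not show whether any group here can move the number far.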